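The compounds below may be only part of what the source reports. "The series", "measured", "known", "first", "only" and "open" are said of these compounds alone.

Measured so far in this series:

compound 1 `O=C(N/N=C/c1ccccn1)c1cccc(Br)c1`: 13500 nM
compound 2 `O=C(NN=C(c1ccccn1)c1ccccn1)c1ccncc1`: 830 nM

In an ADME assay on cells (Homo sapiens) for antiproliferative activity, read by MTT assay (on this read-out higher numbers stand for weaker inhibition and lower numbers for stronger inhibition), compound 2 gives 830 nM, the lower of the two numbers recorded so far. In this assay compound 1 gives 13500 nM, a higher number, and the gap between the two lies beyond the usual scatter. Going by the values given here, the two compounds differ in several places at once, so their pair gives no single counted step and supports no reading of any one change.

Compound 3 `O=C(NN=C(c1ccccn1)c1ccccn1)c1ccccc1` is still to be measured in this assay. It differs from compound 2 in one place: phenyl in place of pyridin-4-yl on a carbonyl carbon. Phenyl in place of pyridin-4-yl on a carbonyl carbon: the rest of compound 2 is kept. Among the compounds with values here, no measured pair isolates this exchange, so the expectation rests on compound 2 alone, whose value in this assay is 830 nM. The step expected here is a 1.4-fold higher number from compound 2 to compound 3 (0.16 log units; within the scatter), a drift toward a higher number that is not expected to go beyond the scatter. Compound 3 is therefore estimated at 1200 nM, with a range from 400 nM to 4000 nM.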

Compound 3, half-maximal inhibitory concentration: 3040 nM
Compound 3: middle estimate off by 2.5-fold (0.40 log units), on the low side; low and high end bracket the measured number.
By their numbers in this assay, from the lowest: compound 2; then compound 3; then compound 1.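

In this assay, going by these compounds alone, phenyl in place of pyridin-4-yl on a carbonyl carbon gives a 3.7-fold higher number from compound 2 to compound 3 (0.56 log units; beyond the scatter) and is the first single-place step, showing that this position responds to the exchange. The exchange keeps a six-membered aromatic ring and leaves the net charge unchanged, while the ring nitrogen, counted as a hydrogen-bond acceptor, leaves with pyridin-4-yl; in this one pair, the group with that ring nitrogen goes with the lower number. No measurement at hand accounts for the step, and this single pair ties no property to that ring nitrogen.

Still open, from the compounds shown here alone, is where pyridin-3-yl, or a phenyl carrying an amine or a carboxylic acid, would fall on this carbonyl carbon relative to compound 2 and compound 3. Also open, going by these compounds, is whether the step carries over to the core of compound 1, which differs from compound 3 in more than one place and so gives no reading of this exchange.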